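A few compounds are considered here, and "the series" means these few. Any claim that something is new, unique, unknown or untested is made for them only; others in the source may bear on it.

In a functional assay on MCF7 cells (Homo sapiens) for antiproliferative activity (a higher number here means a weaker inhibitor, a lower number a stronger inhibitor), compound 3 `COc1ccc(Nc2ccc3cc(NC(=O)c4ccc(OC(C)=O)c(CC=C(C)C)c4)c(=O)oc3c2C)cc1` gives only a limit, > 100000 nM, so no number is known for it. This is the limit of > 100000 nM in this assay, at which 1 of the 3 values shown sits. Compound 1 `COc1ccc(Oc2ccc3cc(NC(=O)c4ccc(O)c(CC=C(C)C)c4)c(=O)oc3c2C)cc1` and compound 2 `CC(C)=CCc1cc(C(=O)Nc2cc3ccc(Oc4ccc(C(C)(C)C)cc4)c(C)c3oc2=O)ccc1O` both carry a free hydroxy where compound 3 carries an acetylated oxygen, and they also differ from compound 3 in the linker between the two outer rings. Compound 1 gives 6510 nM. Compound 2 gives 20600 nM. Within the data shown here, the one measured step between them, a 3.2-fold higher number from compound 1 to compound 2 (0.50 log units; beyond the scatter), concerns the group on the far aromatic ring and says nothing about the acetyl.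

Compound 4 `COc1ccc(Nc2ccc3cc(NC(=O)c4ccc(O)c(CC=C(C)C)c4)c(=O)oc3c2C)cc1` arises from compound 3 by hydrogen in place of acetyl on an oxygen on an aromatic ring; it is the free phenol matching compound 3. Among the measured compounds shown here, no measured step touches the acetyl, so the size of this move cannot be read directly from the measurements. What the measurements do show is that both compounds with a free hydroxy, compound 1 and compound 2, give a number. Compound 3, the acetylated one, gives only a limit. A lower number, beyond the scatter, is therefore expected for compound 4, an at least 4.0-fold lower number from compound 3 to compound 4 (0.60 log units; beyond the scatter), though the limit on compound 3 leaves the size of the step uncertain. Compound 4 is estimated at 25000 nM, within 4000 nM to 150000 nM.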

Compound 4, half-maximal inhibitory concentration: > 100000 nM
Compound 4: only a limit was reported; the forecaster's own chance of this, stated with the estimate: 30%; middle value at least 4.0-fold (0.60 log units) from the limit.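

In this assay compound 4 gives > 100000 nM, which is a limit of the assay and not a number. Hydrogen in place of acetyl thus leaves compound 4 at the same limit as compound 3, so the steps linking the two cannot be read, and a free hydroxy alone does not bring a measurable number: the limit of > 100000 nM in this assay, at which 2 of the 4 values shown sit. What can be read lies at the other end of the molecule, where, with the free hydroxy kept, (4-methoxyphenyl)amino in place of 4-methoxyphenoxy gives an at least 15-fold higher number from compound 1 to compound 4 (1.18 log units; beyond the scatter), and the same group in place of 4-(tert-butyl)phenoxy gives an at least 4.8-fold higher number from compound 2 to compound 4 (0.68 log units; beyond the scatter), so the far group on the aromatic carbon matters more here than the earlier tert-butyl for methoxy swap could show.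

As far as these compounds go, whether acetoxy to hydroxy has any effect at all stays open while compound 3 and compound 4 both rest on a limit. Also open, from the compounds shown here alone, is how a thioether or a methylamino link would read at that aromatic carbon, and whether a (4-(tert-butyl)phenyl)amino group would likewise sit far weaker than compound 2.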